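Removing a Trifluoromethyl From an Inactive Macrocyclic Aniline

This account rests on a few compounds, and the source may have more. Where it says the series, first, only, none or still open, it means among the compounds named here.

Compound 1, `FC(F)(F)c1ccc(COc2cccc(Nc3ncnc4cc5c(cc34)OCCOCCO5)c2)cc1`, was tested in a functional assay on DU-145 cells (Homo sapiens) for antiproliferative activity, read by MTT assay, with a stated time of 72 h; on this read-out higher numbers stand for weaker inhibition and lower numbers for stronger inhibition. In this assay compound 1 gives only a limit of the assay, > 100000 nM, and no number. That limit is the position described by the limit of > 100000 nM in this assay, at which 1 of the 2 values shown sits, so compound 1 stands at the weak end of what is shown. The other measured compound, compound 2, `FC(F)(F)c1ccc(COc2ccc(Nc3ncnc4cc5c(cc34)OCCOCCOCCOCCO5)cc2)cc1`, carries a longer chain in its macrocycle and a different attachment of the aniline; in this assay compound 2 gives 8800 nM. Compound 2 is not joined to compound 1 by any single change, so the two values simply stand side by side.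

The unmeasured compound 3, `c1ccc(COc2cccc(Nc3ncnc4cc5c(cc34)OCCOCCO5)c2)cc1`, differs from compound 1 in one place: hydrogen in place of trifluoromethyl on an aromatic carbon. Going by the values given here, no measured pair shows such a change here, so there is nothing to copy from. Given that compound 1 reads only as > 100000 nM, the step of a number no higher from compound 1 to compound 3 (the limit leaves the size open) is expected to be none beyond the scatter. Compound 3 is therefore estimated at 100000 nM, within a range from 30000 nM to 300000 nM, and most likely it too would be reported only as a limit.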

Compound 3, half-maximal inhibitory concentration: > 100000 nM
Compound 3: no number, only a limit; the forecaster's own chance of this, stated with the estimate: 70%; the middle value sits exactly at the limit.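

Going by these compounds alone, compound 1 and compound 3 each give only a limit and no number, so no step between them can be read. Both stand at the weak end of what is shown: the limit of > 100000 nM in this assay, at which 2 of the 3 values shown sit. On these data alone, whether hydrogen in place of trifluoromethyl would shift the value of a compound giving a true number remains open.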